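Carbamate to Methyl Urea: An Expected Step

The source may hold more compounds than are shown below. What is called first, only, known or untested is meant among the compounds shown, and "the series" means these compounds.

Compound 1, `COc1ccc([N+](=O)[O-])cc1CSc1nc2cc(NC(=O)NC(C)(C)C)ccc2n1C1CC1`: in an assay on isolated protein for inhibition of Gonadotropin-releasing hormone receptor (Rattus norvegicus) (on this read-out lower numbers stand for stronger inhibition and higher numbers for weaker inhibition), compound 1 gives 860 nM.
Compound 2, `COc1ccc([N+](=O)[O-])cc1CSc1nc2cc(NC(=O)OC(C)(C)C)ccc2n1C(C)C`: in this assay compound 2 gives 710 nM.

Compound 2 has the lower of the two numbers, but its gap to compound 1 lies within the scatter, so the two cannot be told apart here. Compound 3, `CNC(=O)Nc1ccc2c(c1)nc(SCc1cc([N+](=O)[O-])ccc1OC)n2C(C)C`, differs from compound 2 in one place: methylamino in place of tert-butoxy on a carbonyl carbon. Among the compounds with values here, no measured pair shows this change, so the expectation rests on the two values alone. In this assay a small step toward weaker inhibition is expected for compound 3, a 1.7-fold higher number from compound 2 to compound 3 (0.23 log units; within the scatter). Compound 3 is estimated at 1200 nM, between 400 nM and 4000 nM.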

Compound 3, half-maximal inhibitory concentration: > 10000 nM
Compound 3 gave a limit, no number; the forecaster's own chance of this, stated with the estimate: 5%; middle value at least 8.3-fold (0.92 log units) away from the limit.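

The earlier compounds shown here gave no step in one place, and this pair shows that the group on this carbonyl carbon strongly affects the result in this assay: the change of tert-butoxy to methylamino brings an at least 14-fold higher number from compound 2 to compound 3 (1.14 log units; beyond the scatter). The value for compound 3 is a limit of the assay and not a number: the limit of > 10000 nM in this assay, at which 1 of the 3 values shown sits.

The compounds shown do not separate the loss of the tert-butoxy carbons from the entry of the nitrogen. As far as these compounds go, a methoxy group on this carbonyl carbon would separate these two, and how it would read remains open.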